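The compounds below may be only part of what the source reports. "The series", "measured", "known", "first", "only" and "open" are said of these compounds alone.

Measured: compound 1 `COc1cccc(C(=O)c2ccc(OC)c(OC(=O)CCC(=O)OC[C@@H]3C=C[C@H](n4cc(C)c(=O)[nH]c4=O)O3)c2)c1`, 770 nM in a functional assay on SGC-7901 cells (Homo sapiens) for antiproliferative activity, read by MTT assay, with a stated time of 48 h; on this read-out lower numbers stand for stronger inhibition and higher numbers for weaker inhibition; compound 2 `COc1ccc(C(=O)c2ccc(F)cc2)cc1OCC(=O)OC[C@@H]1C=C[C@H](n2cc(C)c(=O)[nH]c2=O)O1`, 29100 nM; compound 3 `COc1ccc(C(=O)c2ccc([N+](=O)[O-])cc2)cc1OC(=O)CCC(=O)OC[C@@H]1C=C[C@H](n2cc(C)c(=O)[nH]c2=O)O1`, 10200 nM.

Compound 2 stands highest of the three numbers, nearest to compound 3 and furthest from compound 1. Compound 4 `COc1ccc(C(=O)c2ccc([N+](=O)[O-])cc2)cc1OCC(=O)OC[C@@H]1C=C[C@H](n2cc(C)c(=O)[nH]c2=O)O1` differs from compound 2 by nitro in place of fluoro on an aromatic carbon. Among the measured compounds shown here, the only measured step with a nitro group entering is a 13-fold higher number from compound 1 to compound 3 (1.12 log units; beyond the scatter), but there the group leaving is methoxy and its place differs, so it speaks to the present change only loosely. Compound 3 carries the nitro group on a different ester linker and gives 10200 nM. For the measured compounds named here, no direct precedent exists for fluoro to nitro; no step beyond the scatter is expected, a 1.2-fold higher number from compound 2 to compound 4 (0.08 log units; within the scatter). Compound 4 is estimated at 35000 nM (range 10000 nM to 120000 nM).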

Compound 4, half-maximal inhibitory concentration: 48100 nM
Beside the measured number, compound 4's estimate is 1.4-fold (0.14 log units) below it; measured number inside the range.
By their numbers in this assay, from the lowest: compound 1; then compound 3; then compounds 2 and 4 (each within the scatter of the next).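

In this assay, 4-fluorophenyl to 4-nitrophenyl on the same ester linker gives a 1.7-fold higher number from compound 2 to compound 4 (0.22 log units; within the scatter), so fluoro and nitro cannot be told apart at this aromatic carbon, para to a large group. Among the compounds shown here, this is the first reading of this exchange alone, with no other change in the structure. No measured data explain this result.

An amine or a carboxylic acid at this position remains untested among the compounds shown. From the compounds shown here alone, whether fluoro and nitro also match on the linker of compound 3 remains open.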